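This account rests on a few compounds, and the source may have more. Where it says the series, first, only, none or still open, it means among the compounds named here.

Compound 1 `O=C(/C=C/c1cccc(NC(=S)Nc2ccccc2)c1)C[C@@H]1O[C@H](CO)[C@@H](O)[C@H](O)[C@H]1O` and compound 2 `O=C(/C=C/c1cccc(NC(=O)Nc2ccccc2)c1)C[C@@H]1O[C@H](CO)[C@@H](O)[C@H](O)[C@H]1O` share a core and differ in one place, the change (a group of 9 heavy atoms (7 carbon, 1 nitrogen, 1 oxygen; one six-membered aromatic ring of carbon only) in place of a group of 9 heavy atoms (7 carbon, 1 nitrogen, 1 sulfur; one six-membered aromatic ring of carbon only), on a nitrogen on an aromatic ring). In an ADME assay on Vero cells (Chlorocebus sabaeus) for cytotoxicity, read by resazurin assay, with a stated time of 2 days (a higher number here means that more compound is tolerated, a lower number that less compound is tolerated), compound 1 gives 371000 nM, and compound 2 gives 373000 nM, so the step of a 1.0-fold higher number from compound 1 to compound 2 (0.00 log units; within the scatter) is one that the measurement cannot separate from repetition. Compound 3 `CC(=O)O[C@@H]1[C@@H](OC(C)=O)[C@H](OC(C)=O)CO[C@H]1CC(=O)/C=C/c1cccc(NC(=S)Nc2ccccc2)c1` sits on a different core; how the two cores differ is not broken down here. In this assay compound 3 gives 58700 nM, the lowest of the three numbers, beyond the scatter from both others. Compound 4 `CC(=O)O[C@@H]1[C@@H](OC(C)=O)[C@H](OC(C)=O)CO[C@H]1CC(=O)/C=C/c1cccc(NC(=O)Nc2ccccc2)c1` is compound 3 with the change (a group of 9 heavy atoms (7 carbon, 1 nitrogen, 1 oxygen; one six-membered aromatic ring of carbon only) in place of a group of 9 heavy atoms (7 carbon, 1 nitrogen, 1 sulfur; one six-membered aromatic ring of carbon only), on a nitrogen on an aromatic ring), the same change made from compound 1 to compound 2. For compound 4 the step of a 1.0-fold higher number from compound 3 to compound 4 (0.01 log units; within the scatter) is expected to be flat, because a 1.0-fold higher number from compound 1 to compound 2 (0.00 log units; within the scatter) showed no movement on the other core. Compound 4 is therefore estimated at 60000 nM, within 30000 nM to 120000 nM.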

Compound 4, half-maximal cytotoxic concentration: 102000 nM
For compound 4 the middle estimate is 1.7-fold (0.23 log units) below the measured one; low and high end bracket the measured number.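

In this assay, putting phenylcarbamoyl in place of the sulfur-containing group, on a nitrogen on an aromatic ring, gives a 1.7-fold higher number from compound 3 to compound 4 (0.24 log units; within the scatter), a step that repetition alone could produce. Set beside the earlier step, it cannot be told apart from it: the same change on two cores in this assay, a 1.0-fold higher number (0.00 log units; within the scatter) from compound 1 to compound 2 and a 1.7-fold higher number (0.24 log units; within the scatter) from compound 3 to compound 4, 1.7-fold (0.24 log units) apart, within the scatter of two such steps. In this series the change therefore carried from one core to the other without a detectable difference in tolerated concentration, but two cores show this only for these two pairs and do not show that it would hold on any further core or explain why the step stays flat.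

The compounds shown leave open whether the same holds when a longer alkyl chain replaces the terminal phenyl ring. They also leave open what an amine or a carboxylic acid on that ring would do.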